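The compounds below may be only part of what the source reports. "The series", "measured", "known", "first", "only" and "open" are said of these compounds alone.

Measured compounds:
compound 1 `COc1ccc(Oc2ccc([N+](=O)[O-])cc2-c2ccsc2S(=O)(=O)N2CCN(C(=S)Nc3ccc([N+](=O)[O-])cc3)CC2)cc1OC`, in a functional assay on HeLa cells (Homo sapiens) for inhibition, read by CCK-8 assay, with a stated time of 48 h (on this read-out lower numbers stand for stronger inhibition and higher numbers for weaker inhibition), compound 1 gives > 50000 nM, a limit of the assay.
compound 2 `O=C(NCCNS(=O)(=O)c1ccc(-c2ccccc2Oc2ccc([N+](=O)[O-])c([N+](=O)[O-])c2)s1)Nc1cc(Cl)cc(Cl)c1`, in this assay compound 2 gives > 20000 nM, likewise a limit.
compound 3 `COc1ccc(Oc2ccccc2-c2ccsc2S(=O)(=O)N2CCN(C(=S)Nc3ccc([N+](=O)[O-])cc3)CC2)cc1OC`, in this assay compound 3 gives > 50000 nM, again a limit.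

All three values shown are limits, not numbers: two sit at the limit of > 50000 nM in this assay, at which 2 of the 3 values shown sit, and one at the limit of > 20000 nM in this assay, at which 1 of the 3 values shown sits. Compound 3 therefore stands nowhere readable on the scale; its value only says that no half-maximal inhibition was reached within the tested range. For the measured compounds named here, the one step between measured compounds that differ in a single place, a step that the two limits leave unreadable from compound 1 to compound 3, is hydrogen in place of nitro on an aromatic carbon, and both limits leave its size unreadable.

Compound 4 `COc1ccc(Oc2ccccc2-c2ccsc2S(=O)(=O)N2CCN(C(=S)Nc3ccc(Cl)cc3)CC2)cc1OC` differs from compound 3 by chloro in place of nitro on an aromatic carbon. No measured step bears on this change: the only step shown concerns a different position, and its size is hidden by two limits. The expectation for compound 4 in this assay thus rests solely on the position of compound 3 at its limit, and the step of a number no higher from compound 3 to compound 4 (the limit leaves the size open) is expected to be nothing readable beyond the scatter. Compound 4 is estimated at 50000 nM, with a range from 10000 nM to 200000 nM, most likely reported again as a limit.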

Compound 4, half-maximal inhibitory concentration: > 50000 nM
Compound 4: a limit, no number; the forecaster's own chance of this, stated with the estimate: 75%; the middle value sits exactly at the limit.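

In this assay compound 4 gives > 50000 nM, a limit and not a number. Compound 3 also stands at a limit, so no step can be read between compound 3 and compound 4. The compounds shown leave open how 4-chlorophenyl and 4-nitrophenyl compare here, and which change, if any, would give a readable value.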